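The compounds below may be only part of what the source reports. "The series", "measured", "known", "first", "only" and "open" are said of these compounds alone.

Working notes on the series. The shared core is that of compound 1 `O=C1C(NC2CCCC2)=CC(=O)c2c1nc1n2[C@H]2OC[C@@H](O)[C@H]2OC1`. In a functional assay on HeLa cells (Homo sapiens) for inhibition, read by sulforhodamine B assay (a lower number here means a stronger inhibitor, a higher number a weaker inhibitor), compound 1 gives only a limit of the assay, > 16000 nM. Compound 2 `O=C1C(NC2CCCCC2)=CC(=O)c2c1nc1n2[C@H]2OC[C@@H](O)[C@H]2OC1` carries cyclohexyl in place of cyclopentyl on an amine nitrogen. In this assay compound 2 likewise gives only a limit, > 16000 nM. The step that the two limits leave unreadable from compound 1 to compound 2 cannot be read, since both values sit at the limit of > 16000 nM in this assay, at which 2 of the 2 values shown sit; compound 2 therefore stands at the limit, with no number of its own against which a change could be set.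

Compound 3 `O=C1C(Nc2ccc(Br)cc2)=CC(=O)c2c1nc1n2[C@H]2OC[C@@H](O)[C@H]2OC1` is the next in the line, differing from compound 2 by 4-bromophenyl in place of cyclohexyl on an amine nitrogen. No measured step bears on this change: the only step shown, a step that the two limits leave unreadable from compound 1 to compound 2, is unreadable, and no aromatic group on the amine nitrogen has been measured in this series. Among the compounds with values here, no direction in this assay can be read from the numbers so far. Compound 3 is expected to remain near the limit, with an estimated 20000 nM between 4000 nM and 80000 nM. The step from compound 2 to compound 3 that this expectation implies is a step that the limit leaves unreadable from compound 2 to compound 3.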

Compound 3, half-maximal inhibitory concentration: 5220 nM
For compound 3 the middle estimate is 3.8-fold (0.58 log units) above the measured one; low and high end bracket the measured number.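

In this assay the amine nitrogen of the shared core proves responsive to the group it carries, which compounds 1 and 2 could not show: 4-bromophenyl in place of cyclohexyl gives an at least 3.0-fold lower number from compound 2 to compound 3 (0.48 log units; beyond the scatter), and 4-bromophenyl in place of cyclopentyl gives an at least 3.0-fold lower number from compound 1 to compound 3 (0.48 log units; beyond the scatter). Both steps are minimum sizes, so the real change may be larger, and compound 3 is the only one of the three with a number of its own. The two non-aromatic carbon rings remain unresolved against each other, and both steps rest on limits rather than on numbers: the limit of > 16000 nM in this assay, at which 2 of the 3 values shown sit.

The compounds shown do not separate the contribution of the aromatic ring from that of the bromine, so phenyl without bromine, or chlorophenyl or methoxyphenyl in its place, would be needed to tell which part of the change carries the step. From the compounds shown here alone, whether benzyl or a longer chain on the same amine nitrogen would also give a readable number stays open, and a single aromatic example supports no trend.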